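Removing one aryl methoxy from compound 2

This account rests on a few compounds, and the source may have more. Where it says the series, first, only, none or still open, it means among the compounds named here.

Within this series, compound 1 `COCc1cc(OC)c(-c2csc3c(N(CC4CC4)CC4CCOC4)c(OC)nn23)c(OC)c1` gives 48 nM in an assay on HEK293 cells for displacement of a labelled ligand from corticotropin-releasing factor receptor 1 (Homo sapiens), read by scintillation proximity assay, with a stated time of 2 h; a higher number here means a weaker inhibitor, a lower number a stronger inhibitor. Compound 2 `CCCN(c1c(OC)nn2c(-c3c(OC)cc(COC)cc3OC)csc12)C1CCOCC1` gives 98 nM in this assay, and compound 3 `COCc1cc(OC)c(-c2csc3c(N(CC(C)C)C4CCOCC4)c(OC)nn23)c(OC)c1` gives 91 nM. Compound 2 holds the highest of the three numbers: the step of a 2.0-fold higher number from compound 1 to compound 2 (0.31 log units; beyond the scatter) lies beyond the scatter, whereas the step of a 1.1-fold lower number from compound 2 to compound 3 (0.03 log units; within the scatter) is within it, as is the step of a 1.9-fold higher number from compound 1 to compound 3 (0.28 log units; within the scatter).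

Compound 4 `CCCN(c1c(OC)nn2c(-c3ccc(COC)cc3OC)csc12)C1CCOCC1` differs from compound 2 in one place: hydrogen in place of methoxy on an aromatic carbon. All three measured steps alter the amino substituent on the shared core and leave the aryl ring untouched, so none of them bears on this change; the measured data give no direct guide to its size or direction. Lacking such a guide, a modest loss of potency is expected, and the step of a 2.6-fold higher number from compound 2 to compound 4 (0.41 log units; beyond the scatter) is an estimate rather than an extrapolation. Compound 4 is expected to give about 250 nM in this assay, with a range of 80 nM to 800 nM.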

Compound 4, half-maximal inhibitory concentration: 254 nM
Compound 4: middle estimate off by 1.0-fold (0.01 log units), on the low side; the range from low to high includes it.
By their numbers in this assay, from the lowest: compounds 1, 3 and 2 (each within the scatter of the next, the first and the last beyond it); then compound 4.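

The aryl ring now has a measured step of its own: with the amino substituent fixed, hydrogen in place of methoxy on an aromatic carbon ortho to a large group gives a 2.6-fold higher number from compound 2 to compound 4 (0.41 log units; beyond the scatter) in this assay. The earlier steps shown here all lay on the amino substituent, so only this one shows that removing this methoxy alone moves the number beyond the scatter, in the direction of a weaker inhibitor. Nothing measured here accounts for the rise in the number on this removal.

Still open, going by these compounds, is whether a fluoro, chloro or methyl group on this carbon would bring the number back towards that of compound 2 at 98 nM. Also open, on these data alone, is whether the same step would hold with the (cyclopropylmethyl)((oxolan-3-yl)methyl)amino group of compound 1 in place of the (oxan-4-yl)(propyl)amino group.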